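A double bond enters the butyl chain

This account rests on a few compounds, and the source may have more. Where it says the series, first, only, none or still open, it means among the compounds named here.

In a functional assay on P388 cells (Mus musculus) for cytotoxicity (a higher number here means a weaker inhibitor, a lower number a stronger inhibitor), compound 3 (`CCCCN1C(=O)[C@@H](C)NC(=O)[C@@H]2Cc3ccc(OC)c(c3)Oc3ccc(cc3)C[C@@H](C(=O)N2C)N(C)C(=O)[C@H](C)NC(=O)[C@H](Cc2ccc(OC)cc2)N(C)C(=O)[C@@H]1C`) gives 12 nM as its result. Compound 1 (`COc1ccc(C[C@H]2C(=O)N[C@@H](C)C(=O)N(C)[C@H]3Cc4ccc(cc4)Oc4cc(ccc4OC)C[C@@H](C(=O)N[C@H](C)C(=O)N[C@@H](CCSC)C(=O)N2C)N(C)C3=O)cc1`) at 20.4 nM lies within the usual scatter of that number, so the two cannot be ranked. Compound 2 (`CCN1C(=O)[C@@H](C)NC(=O)[C@@H]2Cc3ccc(OC)c(c3)Oc3ccc(cc3)C[C@@H](C(=O)N2C)N(C)C(=O)[C@H](C)NC(=O)[C@H](Cc2ccc(OC)cc2)N(C)C(=O)[C@@H]1C`) gives 43.7 nM and is clearly weaker than compound 3.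

Compound 4 (`C/C=C/CN1C(=O)[C@@H](C)NC(=O)[C@@H]2Cc3ccc(OC)c(c3)Oc3ccc(cc3)C[C@@H](C(=O)N2C)N(C)C(=O)[C@H](C)NC(=O)[C@H](Cc2ccc(OC)cc2)N(C)C(=O)[C@@H]1C`) has not yet been measured. Its difference from compound 3 is prop-1-en-1-yl in place of propyl on a saturated chain carbon bound to an amide-type nitrogen in a ring and amounts to prop-1-en-1-yl in place of propyl on a saturated chain carbon bound to an amide-type nitrogen in a ring. Cut one bond further out, the same difference reads butyl to but-2-en-1-yl.

Among the measured compounds shown here, only one measured step bears on this, and only loosely. The step of a 3.6-fold lower number from compound 2 to compound 3 (0.56 log units; beyond the scatter) was modest but beyond the scatter, and it placed ethyl in place of hydrogen, which lengthened the chain. Here the chain keeps its length and gains a double bond, a kind of change that no measured pair shows. No shift beyond the scatter is therefore expected in this assay and neither direction is clearly favoured. The estimated step is a 1.3-fold higher number from compound 3 to compound 4 (0.10 log units; within the scatter) and stays within the scatter. For compound 4 the estimated value is 15 nM with an expected range from 7 nM to 32 nM in this measurement.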

Compound 4, half-maximal inhibitory concentration: 9.12 nM
For compound 4 the middle estimate is 1.6-fold (0.22 log units) above the measured one; the range from low to high includes it.
By their numbers in this assay, from the lowest: compounds 4, 3 and 1 (each within the scatter of the next, the first and the last beyond it); then compound 2.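

In this assay the double bond brings a 1.3-fold lower number from compound 3 to compound 4 (0.12 log units; within the scatter), so butyl and but-2-en-1-yl cannot be told apart at this place on the amide-type nitrogen, and a chain of this length can carry a double bond with no readable effect on the result. Set against the shorter chain of compound 2, the but-2-en-1-yl chain gives a 4.8-fold lower number from compound 2 to compound 4 (0.68 log units; beyond the scatter), which is slightly larger than a 3.6-fold lower number from compound 2 to compound 3 (0.56 log units; beyond the scatter), so both of the longer chains stand clearly apart from compound 2, whether saturated or not. Nothing available explains why the chain length registers here while the double bond does not.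

The compounds shown leave open how far this tolerance reaches: a hexyl chain, a triple bond as in but-2-yn-1-yl, or the cis form of the double bond could each behave differently at this place. It also remains open whether a chain ending in an amine or a carboxylic acid would fit the same trend, since every chain shown here is built of carbon and hydrogen alone.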